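From compound 3 to compound 4: chloro for bromo

This account rests on a few compounds, and the source may have more. Where it says the series, first, only, none or still open, it means among the compounds named here.

For the measured compounds named here, in a functional assay on DU-145 cells (Homo sapiens) for inhibition, read by trypan blue exclusion, with a stated time of 96 h (a higher number here means a weaker inhibitor of growth, a lower number a stronger inhibitor of growth), compound 1 (`Cc1ccc(S/C(=C/c2ccc(Br)cc2)C(=O)c2ccc(Cl)cc2)cc1`) gives 25000 nM and compound 2 (`O=C(/C(=C\c1ccc(Br)cc1)Sc1ccc(Br)cc1)c1ccc(Cl)cc1`) gives 1000 nM as the lowest number so far. Compound 3 (`O=C(/C(=C\c1ccc(Br)cc1)SCc1ccc(F)cc1)c1ccc(Br)cc1`) gives 25000 nM and stands level with compound 1, together the highest of the three numbers.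

Compound 4 (`O=C(/C(=C\c1ccc(Br)cc1)SCc1ccc(F)cc1)c1ccc(Cl)cc1`) differs from compound 3 by chloro in place of bromo on an aromatic carbon in one place: chloro in place of bromo on an aromatic carbon, para to a large group.

Going by the values given here, the only measured step, a 25-fold lower number from compound 1 to compound 2 (1.40 log units; beyond the scatter) for bromo in place of methyl, is large, but it sits at another aromatic carbon, and no measured step exchanges bromo for chloro.

The expected step is no change at the digits printed from compound 3 to compound 4 (within the scatter) in this assay and thus none beyond the scatter. Compound 4 is estimated at 25000 nM within a range of 10000 nM to 50000 nM for now.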

Compound 4, concentration for 50% growth inhibition: 9000 nM
Compound 4: middle estimate off by 2.8-fold (0.44 log units), on the high side; measured number below the stated range.
By their numbers in this assay, from the lowest: compound 2; then compound 4; then compounds 1 and 3 (each within the scatter of the next).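

In this assay the change from 4-bromophenyl to 4-chlorophenyl on the carbonyl is not silent: it gives a 2.8-fold lower number from compound 3 to compound 4 (0.44 log units; beyond the scatter) and so separates chloro from bromo at this position. With chloro held there, 4-fluorobenzyl on the sulfur gives a 9.0-fold higher number from compound 2 to compound 4 (0.95 log units; beyond the scatter) against 4-bromophenyl but a 2.8-fold lower number from compound 1 to compound 4 (0.44 log units; beyond the scatter) against 4-methylphenyl, so the direction of that exchange depends on the group replaced. No measurement here offers an explanation for these steps.

On these data alone, whether chloro also beats bromo with an aryl group on the sulfur stays open. So does the effect of an amine or a carboxylic acid in place of the chloro.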